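The source may report more compounds than this note shows. Statements on the series, on what has been measured and on what is new or still open speak of the compounds shown alone.

Measured compounds:
- compound 1 `COc1cc2c(Oc3ccc(NC(=O)c4nn(-c5ccccc5)c(=O)cc4C)cc3F)ccnc2cc1OCCCN1CCCC1`: 460 nM
- compound 2 `COc1cc2c(Oc3ccc(NC(=O)c4nn(-c5ccccc5)c(=O)cc4C)cc3F)ccnc2cc1OCCCN1CCCCC1`: 280 nM
- compound 3 `COc1cc2c(Oc3ccc(NC(=O)c4nn(-c5ccccc5)c(=O)cc4C)cc3F)ccnc2cc1OCCCN1CCN(C)CC1`: 360 nM

These three compounds share one core and differ only in the cyclic amine at the end of the chain that hangs from an oxygen on an aromatic ring. In a functional assay on NCI-H460 cells (Homo sapiens) for inhibition, read by MTT assay, with a stated time of 72 h (on this read-out lower numbers stand for stronger inhibition and higher numbers for weaker inhibition), compound 1 gives the highest of the three numbers, but every step among them stays within the scatter: a 1.6-fold lower number from compound 1 to compound 2 (0.22 log units; within the scatter), a 1.3-fold lower number from compound 1 to compound 3 (0.11 log units; within the scatter) and a 1.3-fold higher number from compound 2 to compound 3 (0.11 log units; within the scatter). On these numbers compound 1 is therefore not separated from compound 2 or compound 3.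

Compound 4 `COc1cc2c(Oc3ccc(NC(=O)c4nn(-c5ccccc5C)c(=O)cc4C)cc3F)ccnc2cc1OCCCN1CCCC1` is not yet measured. It keeps the pyrrolidin-1-yl of compound 1 and changes a different part of the molecule: methyl in place of hydrogen on an aromatic carbon. Going by the values given here, none of the measured steps touches this ring; all of them vary the amine, and all of them stayed within the scatter. Among the compounds with values here, there is thus no measured step that bears on this change, and nothing in these data points to a step beyond the scatter in either direction in this assay.

Compound 4 is therefore expected to sit close to compound 1, at an estimated 450 nM, with a range from 150 nM to 1400 nM. This amounts to an expected 1.0-fold lower number from compound 1 to compound 4 (0.01 log units; within the scatter), a step that may well fall within the scatter.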

Compound 4, half-maximal inhibitory concentration: 1590 nM
For compound 4 the middle estimate is 3.5-fold (0.55 log units) below the measured one; measured number outside the range, above it.
By their numbers in this assay, from the lowest: compounds 2, 3 and 1 (each within the scatter of the next); then compound 4.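

In this assay, going by these compounds alone, replacing phenyl with 2-methylphenyl gives a 3.5-fold higher number from compound 1 to compound 4 (0.54 log units; beyond the scatter) and so produces the first step in this set that lies beyond the scatter, while the swaps among the cyclic amines all stayed within it. The earlier compounds shown here left this ring untouched, so they could not show that it responds to so small an edit: a single methyl, ortho to a large group, is enough to weaken inhibition modestly on this read-out. Nothing in the data shown gives a reason for this rise.

Still open, going by these compounds, is whether the effect belongs to methyl in particular, or whether a fluorine atom or a methoxy group on the same aromatic carbon would give a step of similar size. On these data alone, it is also open whether this methyl would give a similar step when paired with the piperidin-1-yl of compound 2 or the 4-methylpiperazin-1-yl of compound 3, rather than the pyrrolidin-1-yl of compound 1.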